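The source may hold more compounds than are shown below. What is called first, only, known or untested is meant among the compounds shown, and "the series" means these compounds.

In a functional assay on the whole organism with Rattus norvegicus as the target (on this read-out higher numbers stand for an effect only at larger amounts of compound and lower numbers for an effect already at smaller amounts), compound 1 `COc1cc(N)c(Cl)cc1C(=O)NCCN(C)CC1CCCCC1` gives 3 mg/kg and compound 2 `CCCCN(CCNC(=O)c1cc(Cl)c(N)cc1OC)Cc1ccc(Cl)cc1` gives 20 mg/kg. Compound 3 `COc1ccc(OC)c(C(=O)NCCN(C)Cc2ccccc2)c1` gives 3 mg/kg, level with compound 1, and together the two hold the lowest of the three numbers. The number for compound 2 stands higher than both, beyond the usual scatter.

Compound 4 `COc1ccc(S(C)(=O)=O)cc1C(=O)NCCN(C)Cc1ccccc1` has not yet been measured in this assay. It differs from compound 3 in one place: methylsulfonyl in place of methoxy on an aromatic carbon. In words, methylsulfonyl stands in place of methoxy on an aromatic carbon, meta to a large group and para to a methoxy group.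

Among the measured compounds shown here, no two measured compounds differ in only one place, so the data offer no direct guide to the size of this change. The starting point is compound 3 at 3 mg/kg, and the highest measured number is that of compound 2 at 20 mg/kg. With so little to go on, only a small rise is expected, and the estimated step is a 1.7-fold higher number from compound 3 to compound 4 (0.22 log units; within the scatter), which would stay within the usual scatter. For compound 4 the expected value is 5 mg/kg, with an estimated range from 1.5 mg/kg to 20 mg/kg.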

Compound 4, dose for half-maximal effect: 3 mg/kg
Estimate against measurement, compound 4: 1.7-fold (0.22 log units) above; the range from low to high includes it.
By their numbers in this assay, from the lowest: compounds 1, 3 and 4 (each within the scatter of the next); then compound 2.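

In this assay, among the compounds shown here, putting methylsulfonyl in place of methoxy on this aromatic carbon, meta to a large group and para to a methoxy group, gives no change at the digits printed from compound 3 to compound 4 (within the scatter), the first step in this set that isolates a change in one place. The carbon therefore carries either group with no separable difference in this read-out, even though the entering group has 4 heavy atoms and 2 hydrogen-bond acceptors, against 2 heavy atoms and 1 hydrogen-bond acceptor for the group that leaves. Nothing measured here explains why the read-out stays level across this exchange.

From the compounds shown here alone, whether the same carbon would accept an amine, a carboxylic acid or a longer alkoxy chain remains open, since a single step cannot show how far this tolerance extends. Going by these compounds, it is also open whether methylsulfonyl would read the same way with the benzyl group on the amine replaced by the cyclohexylmethyl group of compound 1 or by the 4-chlorobenzyl and butyl groups of compound 2.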